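The source may report more compounds than this note shows. Statements on the series, on what has been measured and on what is new or still open speak of the compounds shown alone.

Compound 1 `CSc1nc(-c2cccs2)c(C#N)c(=O)n1C` gives 72 ug/mL in a functional assay, with a stated time of 10 min; on this read-out lower numbers stand for stronger inhibition and higher numbers for weaker inhibition.
Compound 2 `CCOC(=O)c1cnn(-c2nc(-c3ccccc3Cl)c(C#N)c(=O)n2C)c1N` gives 98 ug/mL in this assay.

Compound 2 has the highest of the two numbers, but its nearest neighbour, compound 1, differs from it only within the usual scatter, so the two cannot be told apart. Compound 3 `CCOC(=O)c1cnn(-c2nc(-c3ccc(Cl)cc3)c(C#N)c(=O)n2C)c1N` has not been measured. It differs from compound 2 in one place: 4-chlorophenyl in place of 2-chlorophenyl on an aromatic carbon. No pair of measured compounds isolates such a change, so there is no shown step to lean on. Compound 3 is therefore expected to give a number close to that of compound 2, with a step of a 1.1-fold lower number from compound 2 to compound 3 (0.04 log units; within the scatter) in this assay that stays within the scatter rather than pointing clearly either way. The estimate for compound 3 is 90 ug/mL, with a range from 40 ug/mL to 200 ug/mL.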

Compound 3, half-maximal inhibitory concentration: 94 ug/mL
Compound 3: middle estimate off by 1.0-fold (0.02 log units), on the low side; the measured number falls inside the stated range.
By their numbers in this assay, from the lowest: compounds 1, 3 and 2 (each within the scatter of the next).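

In this assay, putting 4-chlorophenyl in place of 2-chlorophenyl gives a 1.0-fold lower number from compound 2 to compound 3 (0.02 log units; within the scatter) and stays within the scatter. Going by these compounds alone, this is the first pair to isolate a single change at this position, and it shows that the read-out does not separate these two chlorophenyl groups on the shared core. No evidence on hand bears on this result.

The compounds shown leave open whether a different group at this position, such as an unsubstituted phenyl, a methoxyphenyl or an amine, would give a number beyond the scatter from that of compound 2.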